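A few compounds are considered here, and "the series" means these few. Any claim that something is new, unique, unknown or untested is made for them only; others in the source may bear on it.

In an ADME assay on Huh-7 cells (Homo sapiens) for cytotoxicity, with a stated time of 72 h (a lower number here means that less compound is tolerated, a higher number that more compound is tolerated), compound 3, `CCC(C)n1nc(-c2cccs2)c(O)c(C2=NS(=O)(=O)c3cc(NS(C)(=O)=O)ccc3N2)c1=O`, gives > 33000 nM, which is a limit and not a number. Compound 3 thus stands at the limit of > 33000 nM in this assay, at which 2 of the 3 values shown sit. Compound 1, `CS(=O)(=O)Nc1ccc2c(c1)S(=O)(=O)N=C(c1c(O)c(-c3cccs3)nn(CCC3CC3)c1=O)N2`, gives > 33000 nM, also a limit. Compound 2, `CS(=O)(=O)Nc1ccc2c(c1)S(=O)(=O)N=C(c1c(O)c(-c3cccs3)nn(CC3CCC3)c1=O)N2`, gives > 1000 nM, a limit again, and so stands at the limit of > 1000 nM in this assay, at which 1 of the 3 values shown sits.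

Compound 4, `CS(=O)(=O)Nc1ccc2c(c1)S(=O)(=O)N=C(c1c(O)c(-c3cccs3)nn(CC3(C(F)(F)F)CCC3)c1=O)N2`, carries (1-(trifluoromethyl)cyclobutyl)methyl in place of sec-butyl on an aromatic nitrogen. The three measured steps all change the group on an aromatic nitrogen, and so they are the ones that bear on this change: a step that the two limits leave unreadable from compound 1 to compound 2, a step that the two limits leave unreadable from compound 1 to compound 3 and a step that the two limits leave unreadable from compound 2 to compound 3. None of them has a size that can be read, so they set no measure for the new group, which is also larger than any group among the three measured compounds. All that can be drawn from them is that no number has yet appeared in this assay for any group at this place. No shift beyond the scatter is therefore expected, in either direction, and the expected step is a number no higher from compound 3 to compound 4 (the limit leaves the size open). A report of compound 4 as a limit is also the likely outcome. The estimate for compound 4 is 33000 nM. The expected range for compound 4 runs from 10000 nM to 60000 nM.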

Compound 4, half-maximal cytotoxic concentration: > 1000 nM
Compound 4 ended at the assay's limit; the forecaster's own chance of this, stated with the estimate: 80%; the middle value is on the limit's open side.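

Compound 4 is reported only as a limit, so its steps from compound 1, compound 2 and compound 3 cannot be read in this assay. The compounds shown leave open whether the groups on the aromatic nitrogen differ at all in this assay, as all four values are limits and none is a number.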